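From 3-cyanophenyl to 4-methoxyphenyl on a shared core

This account rests on a few compounds, and the source may have more. Where it says the series, first, only, none or still open, it means among the compounds named here.

Three compounds built on one shared core have numbers in an ADME assay on a cell-free system (plasma, Mus musculus) for protein binding, so far. Compound 1 (`CNc1nccc(N2CC[C@H](NC(=O)Nc3ccc(CN(C)C)c(C(F)(F)F)c3)C2)n1`) gives 87.8% and compound 2 (`CNc1nccc(N2CC[C@H](NC(=O)Nc3cc(OC)cc(OC)c3)C2)n1`) gives 96.9% in this test. Compound 3 (`CNc1nccc(N2CC[C@H](NC(=O)Nc3cccc(C#N)c3)C2)n1`) gives 91.5% as its reading, which lies within the scatter of compound 1, while compound 2 keeps a smaller free fraction than compound 3, by a gap beyond the scatter.

The next compound, compound 4 (`CNc1nccc(N2CC[C@H](NC(=O)Nc3ccc(OC)cc3)C2)n1`), has 4-methoxyphenyl in place of 3-cyanophenyl on an amide-type nitrogen. Among the measured compounds shown here, no two measured compounds differ in one place only, so nothing here measures this exchange directly. For the measured compounds named here, the only hint is compound 2, which also carries methoxy groups and gives 96.9% as its reading, so a small move towards more binding is expected. The step expected is a 1.2-fold lower unbound fraction from compound 3 to compound 4 (0.08 log units; within the scatter) and it would stay within the scatter. For compound 4 the estimated value is 93% with an expected range from 88% to 96.5% in this assay.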

Compound 4, plasma protein binding: 82.1%
Estimate against measurement, compound 4: 2.6-fold (0.41 log units) (unbound fraction) below; measured number outside the range, below it.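

The aryl group on the amide-type nitrogen clearly influences this assay: exchanging 3-cyanophenyl for 4-methoxyphenyl gives a 2.1-fold higher unbound fraction from compound 3 to compound 4 (0.32 log units; beyond the scatter), even though both groups have the same heavy-atom count and no net charge. Methoxy substitution alone does not guarantee a high reading, since compound 2, which carries methoxy groups, gives 96.9%, whereas compound 4 gives 82.1%. No supporting measurement is available to explain this shift.

This exchange alters both the substituent and its printed ring position, so the compounds shown cannot separate the effect of replacing nitrile with methoxy from the effect of moving from position 3 to position 4. From the compounds shown here alone, a direct comparison would need 3-methoxyphenyl or 4-cyanophenyl, and how a phenyl ring bearing a carboxylic acid would behave at this nitrogen also remains open.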